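The compounds below may be only part of what the source reports. "The series", "measured", "known", "first", "only" and "open" are said of these compounds alone.

Compound 1 `COc1ccc(F)cc1Nc1cc(NC(=O)Nc2c(Cl)cccc2Cl)ncn1` gives 78% in a functional assay on HCC827 cells (Homo sapiens) for inhibition, read by MTT assay, with a stated time of 48 h, tested at 10 uM; a higher number here means more inhibition at the concentration tested (going by the name of the read-out), a lower number less inhibition. Compound 2 `COc1cc(NC(=O)Nc2cc(Nc3cc(C(F)(F)F)ccc3OC)ncn2)cc(OC)c1` gives 59.7% in this assay. Compound 3 `COc1ccc(Br)cc1Nc1cc(NC(=O)Nc2c(Cl)cccc2Cl)ncn1` gives 53% in this assay.

Compound 3 stands at the low end of these three numbers. Its number and that of compound 2 lie within the usual scatter of each other, so no order can be read between them, whereas the gap to compound 1 is beyond the scatter: a number 25 percentage points lower from compound 1 to compound 3 (beyond the scatter).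

Compound 4 `COc1ccc(C(F)(F)F)cc1Nc1cc(NC(=O)Nc2c(Cl)cccc2Cl)ncn1` differs from compound 3 in one place: trifluoromethyl in place of bromo on an aromatic carbon. Within the data shown here, only one measured step bears on this change, the one from compound 1 to compound 3, in which a number 25 percentage points lower from compound 1 to compound 3 (beyond the scatter). Among the measured compounds shown here, that step concerns a different pair of groups at the same place, so it gives a direction at best; no measured step exchanges bromo for trifluoromethyl. Compound 2 carries a trifluoromethyl at this place with a different urea partner, and its value of 59.7% lies within the scatter of compound 3.

Compound 4 is therefore expected to land close to compound 3, with a number 3 percentage points lower from compound 3 to compound 4 (within the scatter), a step not beyond the scatter. The estimate for compound 4 in this assay is 50%, with a range from 30% to 70%.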

Compound 4, a percentage reported as inhibition, at one concentration (the size of the read-out at that concentration, not a potency): 68.7%
For compound 4 the middle estimate is 18.7 percentage points below the measured one; measured number inside the range.
By their numbers in this assay, from the lowest: compounds 3, 2, 4 and 1 (each within the scatter of the next, the first and the last beyond it).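

At the place para to a methoxy group, trifluoromethyl and bromo can be told apart in this assay, with a number 15.7 percentage points higher from compound 3 to compound 4 (beyond the scatter). Trifluoromethyl and fluoro at this place cannot be told apart, with a number 9.3 percentage points lower from compound 1 to compound 4 (within the scatter), so among the three groups on the 2,6-dichlorophenyl urea, only bromo gives a number separated from another by more than the scatter, and only from the other two. With trifluoromethyl held at this place, the change at the far end of the urea, 2,6-dichlorophenyl in place of 3,5-dimethoxyphenyl, gives a number 9 percentage points higher from compound 2 to compound 4 (within the scatter), so this single pair shows no separation between the two aryl groups.

Nothing among the available data accounts for the separate standing of bromo at this place. As far as these compounds go, it remains open how an amine or a carboxylic acid at this place would read in this assay, or how a longer chain such as ethoxy in place of the methoxy group would, and all these numbers come from one concentration, so they do not give potencies.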